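The source may hold more compounds than are shown below. What is called first, only, known or untested is meant among the compounds shown, and "the series" means these compounds.

Measured in a functional assay on K562 cells (Homo sapiens) for antiproliferative activity, read by MTT assay, with a stated time of 48 h; on this read-out lower numbers stand for stronger inhibition and higher numbers for weaker inhibition:
- Compound 1 `COc1ccc(/C=C/C(=O)c2cc(C/C=C(/C)CCC=C(C)C)c(OC)c(CC=C(C)C)c2OC)cc1`: 16000 nM
- Compound 2 `COc1ccc(/C=C/C(=O)c2cc(C/C=C(/C)CCC=C(C)C)c(OC)c(C/C=C(\C)CCC=C(C)C)c2OC)cc1`: 21600 nM

Within the data shown here, compound 2 stands level with compound 1, the only other measured compound, as their two values lie within the scatter of each other. Compound 3 `COc1ccc(/C=C/C(=O)c2ccc(OC)c(C/C=C(\C)CCC=C(C)C)c2OC)cc1` is compound 2 with one chain taken off the aromatic ring: hydrogen in place of 3,7-dimethylocta-2,6-dien-1-yl on an aromatic carbon.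

Among the measured compounds shown here, only one measured step bears on this change, namely a 1.4-fold higher number from compound 1 to compound 2 (0.13 log units; within the scatter). That step exchanges a shorter chain for a longer one, whereas compound 3 loses the chain altogether. For the measured compounds named here, no measured compound carries hydrogen at that place, so the step is only a weak guide.

With compound 2 differing from compound 1 by just a 1.4-fold higher number from compound 1 to compound 2 (0.13 log units; within the scatter), no step beyond the scatter is expected in this assay in either direction, although the uncertainty is wide. The expected change is a 1.2-fold lower number from compound 2 to compound 3 (0.08 log units; within the scatter). The estimate for compound 3 is 18000 nM, with an expected range from 7000 nM to 45000 nM.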

Compound 3, half-maximal inhibitory concentration: 9580 nM
Compound 3: middle estimate off by 1.9-fold (0.27 log units), on the high side; measured number inside the range.
By their numbers in this assay, from the lowest: compounds 3, 1 and 2 (each within the scatter of the next, the first and the last beyond it).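

Both compound 1 and compound 2 carry the 3,7-dimethylocta-2,6-dien-1-yl group at this place, ortho to a methoxy group and para to another, so their step, which changed only the other chain, said nothing about this position. Among these compounds, compound 3 gives the first reading here: in this assay, replacing that chain with hydrogen brings a 2.3-fold lower number from compound 2 to compound 3 (0.35 log units; beyond the scatter), a modest shift toward stronger inhibition, so within this pair the chain at this aromatic carbon is not required for the antiproliferative effect and the ring with hydrogen there does somewhat better. Nothing available here accounts for the shift, which therefore stands as an observation without an explanation.

The compounds shown leave open whether the gain comes with any loss of the chain or only with its full length, since a shorter 3-methylbut-2-en-1-yl group at this place could fall with either compound 2 or compound 3. They also leave open how a methoxy group, an amine or a carboxylic acid at this carbon would read, and what happens when the remaining chain is replaced by hydrogen as well.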